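The source may report more compounds than this note shows. Statements on the series, on what has been measured and on what is new or still open speak of the compounds shown alone.

Working notes on the series.

The shared core is carried through three compounds. Among the measured compounds shown here, compound 1, `CCOC(=O)C1=Cc2ccccc2OC1(OCc1cc(-c2ccc(OC)cc2)no1)C(F)(F)F`, is the first of them. In a functional assay on HeLa cells (Homo sapiens) for inhibition, read by MTT assay, with a stated time of 24 h (a higher number here means a weaker inhibitor, a lower number a stronger inhibitor), compound 1 gives only a limit, > 150000 nM, and no number. Compound 2, `CCOC(=O)C1=Cc2ccccc2OC1(OCc1cn(-c2ccc(C)cc2)nn1)C(F)(F)F`, differs from compound 1 in the group on the five-membered aromatic ring, and in this assay compound 2 gives 25100 nM. For the measured compounds named here, this is the only number in the set so far; the other entry is the limit described by the limit of > 150000 nM in this assay, at which 1 of the 2 values shown sits, so compound 2 stands alone on the scale and no measured step is known.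

Compound 3, `CCOC(=O)C1=Cc2ccccc2OC1(OCc1cn(CC(=O)Nc2ccc(C)cc2)nn1)C(F)(F)F`, keeps the core of compound 2 and changes the group on the aromatic nitrogen: ((4-methylphenyl)carbamoyl)methyl in place of 4-methylphenyl on an aromatic nitrogen. No step of this kind has been measured in the set, so the size of the change cannot be anchored on anything shown. The expectation is that compound 3 lands near compound 2, with a step of a 1.2-fold higher number from compound 2 to compound 3 (0.08 log units; within the scatter) that may not exceed the usual scatter. Compound 3 is estimated at 30000 nM, within a range from 8000 nM to 150000 nM.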

Compound 3, half-maximal inhibitory concentration: 67400 nM
The estimate for compound 3 lay 2.2-fold (0.35 log units) below the measured number; low and high end bracket the measured number.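

On the aromatic nitrogen of the five-membered aromatic ring with 3 nitrogen, the series now has its first measured step: in this assay, ((4-methylphenyl)carbamoyl)methyl in place of 4-methylphenyl gives a 2.7-fold higher number from compound 2 to compound 3 (0.43 log units; beyond the scatter). The position therefore responds to this change, and the entering group, which keeps the six-membered aromatic ring of carbon only and adds 1 hydrogen-bond donor and 1 hydrogen-bond acceptor, gives a weaker inhibitor that still yields a measured number. Compound 1 gives only a limit and not a number, so the scale rests on two measured compounds: the limit of > 150000 nM in this assay, at which 1 of the 3 values shown sits.

This single step does not separate the contribution of the carbonyl and the amide hydrogen from that of the added length, and a benzyl group or a plain three-carbon chain ending in the same 4-methylphenyl on this nitrogen would be needed to tell them apart. Also open, on these data alone, is whether a carboxylic acid or an amine in place of the 4-methylphenyl end of the entering group would move the number in either direction.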